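Swapping the methylsulfonyl for a nitro group

The source may report more compounds than this note shows. Statements on the series, on what has been measured and on what is new or still open speak of the compounds shown alone.

Measured compounds:
compound 1 `O=C(c1ccc(Cl)c(C(F)(F)F)c1)N1CCC(c2nc3cc(OS(=O)(=O)c4cccc5cnccc45)ccc3[nH]2)CC1`: 210 nM
compound 2 `CS(=O)(=O)c1ccc(C(=O)N2CCC(c3nc4cc(OS(=O)(=O)c5cccc6cnccc56)ccc4[nH]3)CC2)cc1`: 43 nM

Within the data shown here, in an assay on THP-1 cells for antagonist activity at P2X purinoceptor 7 (Homo sapiens), read by ELISA, with a stated time of 30 min (a higher number here means a weaker inhibitor, a lower number a stronger inhibitor), compound 2 gives 43 nM, the lowest of the two numbers so far, while compound 1 gives 210 nM. Among the measured compounds shown here, the single measured step, a 4.9-fold lower number from compound 1 to compound 2 (0.69 log units; beyond the scatter), shows that the group on the carbonyl-bearing ring does shift the number. Compound 3 `O=C(c1ccc([N+](=O)[O-])cc1)N1CCC(c2nc3cc(OS(=O)(=O)c4cccc5cnccc45)ccc3[nH]2)CC1` differs from compound 2 by nitro in place of methylsulfonyl on an aromatic carbon. For the measured compounds named here, no measured step covers a nitro group, so the expected step is small, within the scatter: a 1.4-fold higher number from compound 2 to compound 3 (0.14 log units; within the scatter). Compound 3 is estimated at 60 nM, with a range from 20 nM to 200 nM.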

Compound 3, half-maximal inhibitory concentration: 17 nM
For compound 3 the middle estimate is 3.5-fold (0.55 log units) above the measured one; measured number outside the range, below it.
By their numbers in this assay, from the lowest: compound 3; then compound 2; then compound 1.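

In this assay, methylsulfonyl is not the limit at this position on the aromatic ring: nitro in its place gives a 2.5-fold lower number from compound 2 to compound 3 (0.40 log units; beyond the scatter). The change from the 4-chloro-3-(trifluoromethyl)phenyl group to 4-nitrophenyl gives a 12-fold lower number from compound 1 to compound 3 (1.09 log units; beyond the scatter), so the choice of ring on the carbonyl carbon now separates the three compounds clearly. Nothing measured here explains why nitro gives the lowest number.

Going by these compounds, whether a nitrile, a carboxylic acid or an amine at this position would lower the number further stays open. So does whether the order of these groups would hold with a change elsewhere in the shared core.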